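A few compounds are considered here, and "the series" means these few. Any claim that something is new, unique, unknown or untested is made for them only; others in the source may bear on it.

Measured in an ADME assay on microsomes from liver (Rattus norvegicus) for metabolic stability; on this read-out higher numbers stand for fast clearance and lower numbers for slow clearance:
- compound 1 `CNc1nc(NC2(C#N)CCCCC2)nc(-n2cccn2)n1`: 103 mL/min/kg
- compound 2 `CNc1nc(NC2(C#N)CCCC2)nc(-n2cncn2)n1`: 43 mL/min/kg
- compound 3 `C#CC(CC)(CC)Nc1nc(NC)nc(-n2cncn2)n1`: 22 mL/min/kg

Compound 1 has the highest number of the three, and compound 2 and compound 3 both stand clearly lower. Compound 4 `CNc1nc(Cl)nc(NC2(C#N)CCCCC2)n1` differs from compound 1 in one place, with chloro in place of 1H-pyrazol-1-yl on an aromatic carbon.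

Among the measured compounds shown here, no measured pair makes this exchange. For the measured compounds named here, the only measured step, a 2.0-fold lower number from compound 2 to compound 3 (0.29 log units; within the scatter), concerns a group on a nitrogen, not this place, so it offers little guidance. Compound 1 and compound 2 differ in more than one place, so their gap cannot be pinned on a single group.

Without direct evidence, no change beyond the scatter is expected. Compound 1 already stands at the top with 103 mL/min/kg, which gives only a slight lean towards a lower number. The expected step is a 1.5-fold lower number from compound 1 to compound 4 (0.17 log units; within the scatter). For compound 4 the estimate is 70 mL/min/kg, with an expected range from 30 mL/min/kg to 150 mL/min/kg.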

Compound 4, clearance: 867 mL/min/kg
Compound 4: middle estimate off by 12-fold (1.09 log units), on the low side, and the stated range ends below it.
By their numbers in this assay, from the lowest: compounds 3 and 2 (each within the scatter of the next); then compound 1; then compound 4.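

Replacing 1H-pyrazol-1-yl with chloro on this aromatic carbon, between two ring nitrogen atoms, is far from a neutral exchange: in this assay it gives an 8.4-fold higher number from compound 1 to compound 4 (0.93 log units; beyond the scatter), a step well beyond the usual scatter. Among the compounds shown here, this is the first measured change at this place, and it shows that the group here can move the clearance read-out strongly, with the pyrazole-bearing compound 1 standing far lower than the chloro compound 4. No available measurement says why the number rises so sharply.

Where a methoxy group or a morpholine ring at this place would fall, closer to compound 1 or closer to compound 4, stays open. Also open, going by these compounds, is whether the same exchange would have a similar effect with 1-cyanocyclopentyl in place of the 1-cyanocyclohexyl group on the nitrogen.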